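Methyl to fluoro swap on the aryl ring

The source may report more compounds than this note shows. Statements on the series, on what has been measured and on what is new or still open speak of the compounds shown alone.

In an ADME assay on Vero cells (Chlorocebus sabaeus) for cytotoxicity, read by neutral red uptake, tested at 197 ug/mL (on this read-out higher numbers stand for a weaker effect at the one concentration tested and lower numbers for a stronger effect), compound 1 `O=C1CSC(c2cccc(O)c2)N1CCN1CCCCC1` gives 100% and compound 2 `Cc1ccc(C2SCC(=O)N2CCN2CCCCC2)cc1` gives 85%, the lower of the two numbers. Among the measured compounds shown here, the only measured step, a number 15 percentage points lower from compound 1 to compound 2 (beyond the scatter), covers 4-methylphenyl in place of 3-hydroxyphenyl. Compound 3 `O=C1CSC(c2ccc(F)cc2)N1CCN1CCCCC1` differs from compound 2 by fluoro in place of methyl on an aromatic carbon. For the measured compounds named here, no measured step covers fluoro in place of methyl, so the known step gives only a rough sense of how far a change on this ring moves the read-out. A step of about the scatter or less in either direction is expected, a number 5 percentage points higher from compound 2 to compound 3 (within the scatter). Compound 3 is therefore estimated at 90%, between 75% and 100%.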

Compound 3, a percentage reported as activity, at one concentration (the size of the read-out at that concentration, not a potency): 73%
The estimate for compound 3 lay 17 percentage points above the measured number; measured number below the stated range.
By their numbers in this assay, from the lowest: compound 3; then compound 2; then compound 1.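

In this assay fluoro in place of methyl, para to a large group, gives a number 12 percentage points lower from compound 2 to compound 3 (beyond the scatter) and so a change confined to this one substituent is enough to move the number. Replacing 3-hydroxyphenyl by 4-fluorophenyl gives a number 27 percentage points lower from compound 1 to compound 3 (beyond the scatter) and leaves compound 3 with the lowest number of the three. Nothing measured here accounts for the shift.

Going by these compounds, whether chloro or a nitrile on the same aromatic carbon would lower the number further than fluoro stays open. So does whether fluoro on another carbon of the ring would give the same number as in compound 3.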